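A few compounds are considered here, and "the series" means these few. Any claim that something is new, unique, unknown or untested is made for them only; others in the source may bear on it.

Measured compounds:
compound 1, `CN(C)CCNc1ccnc2cc(OCc3ccc(F)cc3)ccc12`, 580 nM
compound 2, `CCCCCCOc1ccc2c(Cl)ccnc2c1`, 2720 nM
compound 3, `CCOc1ccc2c(NCCN(C)C)ccnc2c1`, 3650 nM

In a functional assay on RKO cells (Homo sapiens) for cytotoxicity, read by MTT assay, with a stated time of 48 h (on this read-out higher numbers stand for weaker inhibition and lower numbers for stronger inhibition), compound 3 gives the highest of the three numbers; compound 2 sits close to it, within the scatter, while compound 1 lies well away. Among the measured compounds shown here, the one step measured from compound 3, a 6.3-fold higher number from compound 1 to compound 3 (0.80 log units; beyond the scatter), concerns a change at the ether side chain: methyl in place of 4-fluorophenyl on a saturated chain carbon bound to an oxygen on an aromatic ring.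

Compound 4, `CCCCCCOc1ccc2c(NCCN(C)C)ccnc2c1`, is not yet measured. It differs from compound 3 by butyl in place of hydrogen on a saturated chain carbon, two bonds along the chain from an oxygen on an aromatic ring, so the ethoxy of compound 3 becomes hexyloxy. For the measured compounds named here, no measured step reads exactly this change. Compound 2 carries the same hexyloxy group but a chlorine where compound 3 has the amine chain, so its value is only a loose guide; the two values of compound 2 and compound 3 stand within the scatter of each other. The step from compound 1 to compound 3 shows that a larger group on that chain carbon went with a clearly lower number, which suggests a step in that direction for compound 4, expected to be modest, a 2.4-fold lower number from compound 3 to compound 4 (0.39 log units; beyond the scatter). Compound 4 is therefore expected to give about 1500 nM, between 500 nM and 4500 nM.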

Compound 4, half-maximal inhibitory concentration: 1120 nM
Estimate against measurement, compound 4: 1.3-fold (0.13 log units) above, and the stated range covers the measured number.
By their numbers in this assay, from the lowest: compounds 1 and 4 (each within the scatter of the next); then compounds 2 and 3 (each within the scatter of the next).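

In this assay, the step from ethoxy to hexyloxy, with butyl in place of hydrogen on the chain carbon, gives a 3.3-fold lower number from compound 3 to compound 4 (0.51 log units; beyond the scatter) and shows directly that an all-carbon extension of this ether chain goes with a lower number, whereas the earlier step at this ether had involved swapping 4-fluorophenyl for methyl. Pentyl in place of 4-fluorophenyl gives a 1.9-fold higher number from compound 1 to compound 4 (0.29 log units; within the scatter) and so the two ether side chains cannot be told apart here, which means that an aromatic ring at the end of the chain is not needed to reach this range among these compounds. The hexyloxy pair adds a second reading, since (2-(dimethylamino)ethyl)amino in place of chloro on an aromatic carbon gives a 2.4-fold lower number from compound 2 to compound 4 (0.39 log units; beyond the scatter) and the amine chain therefore counts for something in this assay even with the long ether in place.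

The compounds shown leave open whether butoxy would fall on the same trend, whether an octyloxy chain would continue it, and how a terminal amine or carboxylic acid on the chain would read. Nothing shown here gives a reason for these shifts.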